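Amide Swap at the Warhead of a Pyrazole Series

The source may report more compounds than this note shows. Statements on the series, on what has been measured and on what is new or still open speak of the compounds shown alone.

Measured compounds:
compound 1, `O=C(CCl)Nc1ccc(Cn2nc(-c3ccc(Oc4ccccc4)cc3)cc2C(=O)O)cc1`, 2500 nM
compound 2, `CCOC(=O)c1cc(-c2ccc(Oc3ccccc3)cc2)nn1Cc1ccc(NC(=O)CCl)cc1`, 400 nM
compound 3, `O=C(CCl)Nc1ccc(Cn2nc(-c3ccc(Oc4ccccc4)cc3)cc2CO)cc1`, 400 nM

The three measured compounds share one core and differ only in the group on the aromatic carbon of that core. In a functional assay on JeKo-1 cells (Homo sapiens) for inhibition, read by luminescence and CellTiter-Glo, with a stated time of 72 h (a higher number here means a weaker inhibitor, a lower number a stronger inhibitor), compound 1 gives 2500 nM. The step of a 6.3-fold lower number from compound 1 to compound 2 (0.80 log units; beyond the scatter) and the step of a 6.3-fold lower number from compound 1 to compound 3 (0.80 log units; beyond the scatter) both move the number down, while no change at the digits printed from compound 2 to compound 3 (within the scatter) shows no separation. Compound 3 therefore stands level with compound 2 at the digits shown, the two of them giving the lowest numbers of the three, with compound 1 the furthest away.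

Compound 4, `C/C=C/C(=O)Nc1ccc(Cn2nc(-c3ccc(Oc4ccccc4)cc3)cc2CO)cc1`, keeps the hydroxymethyl group of compound 3 and changes the other end of the molecule: prop-1-en-1-yl in place of chloromethyl on a carbonyl carbon. None of the three measured steps touches this carbonyl carbon; all of them concern the aromatic carbon on the core. Among the measured compounds shown here, no measured step in this set therefore bears on the change from compound 3 to compound 4, and the expectation rests only on the value of compound 3.

With nothing to anchor a direction, compound 4 is expected to land near compound 3, with the step of a 2.0-fold higher number from compound 3 to compound 4 (0.30 log units; within the scatter) estimated to stay within the usual scatter, though the range is kept wide. Compound 4 is thus estimated at 800 nM, between 250 nM and 3200 nM.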

Compound 4, half-maximal inhibitory concentration: > 60000 nM
Compound 4: no number, only a limit (the forecaster's own chance of this, stated with the estimate: 5%); middle value at least 75-fold (1.87 log units) from the limit.
By their numbers in this assay, from the lowest: compounds 2 and 3 (each within the scatter of the next); then compound 1. At a limit, above all of these: compound 4.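

The group on the carbonyl carbon, which stayed the same across compounds 1 to 3, turns out to weigh far more on the result in this assay than anything seen so far: prop-1-en-1-yl in place of chloromethyl gives an at least 150-fold higher number from compound 3 to compound 4 (2.17 log units; beyond the scatter) while the hydroxymethyl group on the aromatic carbon stays in place. Among the compounds shown here, by comparison, the largest change among the earlier compounds, made on the aromatic carbon, is a 6.3-fold lower number from compound 1 to compound 3 (0.80 log units; beyond the scatter) and runs in the opposite direction, so the chloromethyl carbonyl end of compound 3 cannot be exchanged for this similarly small chain without a large cost in this cell read-out. For compound 4 this is a limit and not a number, which means the full size of the step stays unknown: the limit of > 60000 nM in this assay, at which 1 of the 4 values shown sits.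

The compounds shown leave open whether a plain ethenyl group, a bromomethyl group or a longer chain ending in an amine on this carbonyl carbon would stay close to compound 3 or fall away like compound 4. They also leave open whether the same exchange would cost as much with carboxy or ethoxycarbonyl on the aromatic carbon, and they give no reason for the loss seen here.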